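Adding an Ethoxy Group to Compound 3

The compounds below may be only part of what the source reports. "The series", "measured", "known", "first", "only" and "open" are said of these compounds alone.

Compound 1 `O=C(Nc1cc(Cl)nc(Cl)c1)Nc1cc2ccc(Br)cn2n1` gives 5260 nM
Compound 2 `Cc1cc(NC(=O)Nc2cc(Cl)nc(Cl)c2)cc(C)n1` gives 86200 nM
Compound 3 `O=C(Nc1ccnc(Cl)c1)Nc1cc(Cl)nc(Cl)c1` gives 16100 nM

These three values come from a functional assay on HCT-116 cells (Homo sapiens) for inhibition, read by MTT assay, with a stated time of 72 h, in the presence of a further agent that is not named here (a higher number here means that more compound is needed for the effect, a lower number that less compound is needed), and span a wide range. Compound 3 (16100 nM) stands in the middle of them. Compound 1 (5260 nM) has a lower number and compound 2 (86200 nM) a higher one, and both gaps from compound 3 lie beyond the scatter.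

Compound 4 `CCOc1cc(NC(=O)Nc2cc(Cl)nc(Cl)c2)cc(Cl)n1` has not yet been measured. Its structure departs from that of compound 3 in one place: ethoxy in place of hydrogen on an aromatic carbon. In short, it carries ethoxy in place of hydrogen on an aromatic carbon.

Among the compounds with values here, no measured pair in this small set differs in just one place, so no direct precedent exists for this change. The expectation in this assay is therefore a modest move toward a lower number, near the edge of the scatter, and its direction is held only loosely. The expected change is a step of a 2.0-fold lower number from compound 3 to compound 4 (0.30 log units; within the scatter) that could still prove to be no real change at all. Compound 4 is estimated at 8000 nM within an expected range of 2500 nM to 26000 nM (an estimate, not a measurement).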

Compound 4, half-maximal effective concentration: 6130 nM
Compound 4: middle estimate off by 1.3-fold (0.12 log units), on the high side, and the stated range covers the measured number.
By their numbers in this assay, from the lowest: compounds 1 and 4 (each within the scatter of the next); then compound 3; then compound 2.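

In this assay, within the data shown here, ethoxy in place of hydrogen on an aromatic carbon, next to the ring nitrogen, gives a 2.6-fold lower number from compound 3 to compound 4 (0.42 log units; beyond the scatter) and provides the first comparison in this set in which only one place differs. The earlier compounds shown here could show only a spread of values across structures differing in more than one place, whereas this pair shows that the position accepts ethoxy without any rise in the number and with a modest fall beyond the scatter. The result establishes the direction and size of this single step, but no measurement shown accounts for it.

Going by these compounds, what remains open is whether the fall belongs to ethoxy in particular or would also appear with methoxy, with a longer chain such as propoxy, or with an amine at the same position. A single step also leaves unsettled whether ethoxy would bring a similar change on a different core, such as that of compound 1 or compound 2, or whether the effect depends on the rest of compound 3.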